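Swapping Iodine for Chlorine on a Thiol-Acid Calpain Inhibitor

The source may report more compounds than this note shows. Statements on the series, on what has been measured and on what is new or still open speak of the compounds shown alone.

Measured compounds:
Compound 1, `O=C(O)/C(S)=C/c1ccccc1Cl`: in an assay on isolated protein for inhibition of Calpain-1 catalytic subunit (Sus scrofa) (on this read-out higher numbers stand for weaker inhibition and lower numbers for stronger inhibition), compound 1 gives 20700 nM.
Compound 2, `O=C(O)/C(S)=C/c1ccc(I)cc1`: in this assay compound 2 gives 5200 nM.
Compound 3, `O=C(O)/C(S)=C/c1cccc(Cl)c1`: in this assay compound 3 gives 13100 nM.

All three share one core, an acrylic acid carrying a thiol, joined to a benzene ring that bears a single halogen. They differ only in which halogen sits where on that ring. Compound 2 has the lowest number of the three, and so is the strongest inhibitor here: compound 3 sits higher by more than the usual scatter, and compound 1 higher still, also beyond the scatter.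

Compound 4, `O=C(O)/C(S)=C/c1ccc(Cl)cc1`, has not yet been measured. It differs from compound 2 in one respect: chloro in place of iodo on an aromatic carbon. Within the data shown here, no measured pair shows exactly this exchange of one halogen for another at the same spot, so the size of the step can only be guessed. A modest step toward weaker inhibition is expected, one that may not clearly exceed the scatter; the expected step is a 1.7-fold higher number from compound 2 to compound 4 (0.24 log units; within the scatter). Compound 4 is therefore estimated at 9000 nM, with a plausible range from 4000 nM to 20000 nM.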

Compound 4, half-maximal inhibitory concentration: 15000 nM
Compound 4: middle estimate off by 1.7-fold (0.22 log units), on the low side; low and high end bracket the measured number.
By their numbers in this assay, from the lowest: compound 2; then compounds 3, 4 and 1 (each within the scatter of the next).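

On an aromatic carbon para to a group of 6 heavy atoms, chloro in place of iodo gives a 2.9-fold higher number from compound 2 to compound 4 (0.46 log units; beyond the scatter) in this assay, so at this place the choice of halogen itself moves the number, toward weaker inhibition. This also sharpens the earlier picture: the lead of compound 2 cannot be credited to the place of the halogen alone, since compound 4, with chloro at that same place, falls in one group with compound 3 at 13100 nM and compound 1 at 20700 nM, each within the scatter of the next. Nothing available explains why iodo and chloro differ here.

The compounds shown leave open how a bromo or fluoro group, or a non-halogen such as a methoxy group or an amine, would behave at this place, and two halogens alone cannot establish a trend. They also leave open whether iodo would give a lower number than chloro at the spots that chloro occupies in compound 1 and compound 3.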